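The compounds below may be only part of what the source reports. "The series", "measured", "known", "first", "only" and "open" are said of these compounds alone.

Three compounds share one core. Compound 1 `COc1cc(C#N)cc(Cl)c1Oc1nc(Nc2ccc(C#N)cc2)nc2ccccc12` gives 220000 nM in an ADME assay on MT4 cells (Homo sapiens) for cytotoxicity, read by MTT assay, with a stated time of 4 days (on this read-out lower numbers stand for higher toxicity in this test and higher numbers for lower toxicity in this test), compound 2 `N#Cc1ccc(Nc2nc(Oc3ccc(Br)cc3)c3ccccc3n2)cc1` gives 215000 nM, and compound 3 `CCCOc1cc(C#N)cc(OC)c1Oc1nc(Nc2ccc(C#N)cc2)nc2ccccc12` gives 5200 nM. Compound 2 thus sits close to compound 1 and far from compound 3. One step has been measured so far, a 42-fold lower number from compound 1 to compound 3 (1.63 log units; beyond the scatter). The change between these two compounds is propoxy in place of chloro on an aromatic carbon. Compound 4 `Cc1ccccc1Oc1nc(Nc2ccc(C#N)cc2)nc2ccccc12` differs from compound 2 by 2-methylphenyl in place of 4-bromophenyl on an oxygen on an aromatic ring. That swap exchanges one small group for another of the same size on the same ring, unlike the longer propoxy chain that separates compound 1 from compound 3, so compound 4 is expected to show a 1.1-fold lower number from compound 2 to compound 4 (0.05 log units; within the scatter). Compound 4 is therefore estimated at 190000 nM, within 60000 nM to 400000 nM.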

Compound 4, half-maximal cytotoxic concentration: 355000 nM
The estimate for compound 4 lay 1.9-fold (0.27 log units) below the measured number; measured number inside the range.
By their numbers in this assay, from the lowest: compound 3; then compounds 2, 1 and 4 (each within the scatter of the next).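

In this assay putting 2-methylphenyl in place of 4-bromophenyl on an oxygen on an aromatic ring gives a 1.7-fold higher number from compound 2 to compound 4 (0.22 log units; within the scatter) and so no real shift. For the compounds shown here, two differently substituted phenyl groups therefore read alike at this place, whereas the only earlier step, propoxy in place of chloro, was large. Nothing measured here gives a reason for this result. Still open, going by these compounds, is whether a group other than a phenyl on this oxygen, such as an amine or a longer chain, would leave the number unchanged.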